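Series notes: alkyl to trifluoromethyl on the five-membered ring

A few compounds are considered here, and "the series" means these few. Any claim that something is new, unique, unknown or untested is made for them only; others in the source may bear on it.

Measured compounds and their numbers:
compound 1 `CNC(=O)c1cc(Oc2ccc3c(C)c(-c4noc(C)n4)sc3c2)ccn1` — in an ADME assay on H1-HeLa cells (Homo sapiens) for cytotoxicity, read by MTT assay, with a stated time of 3 days (on this read-out lower numbers stand for higher toxicity in this test and higher numbers for lower toxicity in this test), compound 1 gives > 100000 nM, a limit of the assay.
compound 2 `CNC(=O)c1cc(Oc2ccc3c(C)c(-c4noc(C5CC5)n4)sc3c2)ccn1` — in this assay compound 2 gives 6800 nM.
compound 3 `CNC(=O)c1cc(Oc2ccc3c(C)c(-c4noc(C(C)C)n4)sc3c2)ccn1` — in this assay compound 3 gives 5500 nM.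

Compound 3 holds the lowest of the two numbers shown, but the step of a 1.2-fold lower number from compound 2 to compound 3 (0.09 log units; within the scatter) lies within the scatter, so compounds 2 and 3 are not separated. The two large steps are an at least 14-fold lower number from compound 1 to compound 2 (1.16 log units; beyond the scatter) and an at least 18-fold lower number from compound 1 to compound 3 (1.25 log units; beyond the scatter), both running from the methyl compound to a branched group on the same aromatic carbon; the starting point is the limit (the limit of > 100000 nM in this assay, at which 1 of the 3 values shown sits).

Compound 4 `CNC(=O)c1cc(Oc2ccc3c(C)c(-c4noc(C(F)(F)F)n4)sc3c2)ccn1` is the next variation: trifluoromethyl in place of isopropyl on an aromatic carbon. Among the measured compounds shown here, no measured step covers trifluoromethyl at this carbon. The available steps show that branched carbon groups of three heavy atoms sit close together, while methyl lies at the limit. Trifluoromethyl is a one-carbon group like methyl but with four heavy atoms; the expectation is therefore intermediate, and the estimated step of a 3.6-fold higher number from compound 3 to compound 4 (0.56 log units; beyond the scatter) is toward a higher number. Compound 4 is expected to give 20000 nM, with a range from 5000 nM to 100000 nM in this assay.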

Compound 4, half-maximal cytotoxic concentration: > 100000 nM
Compound 4: only a limit was reported; the forecaster's own chance of this, stated with the estimate: 25%; at least 5.0-fold (0.69 log units) between middle value and limit.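

In this assay compound 4 gives > 100000 nM, which is a limit of the assay and not a number. The heavy-atom count alone therefore does not set the read-out at this carbon: the change from isopropyl to trifluoromethyl adds a heavy atom yet gives an at least 18-fold higher number from compound 3 to compound 4 (1.25 log units; beyond the scatter), and the change from cyclopropyl gives an at least 14-fold higher number from compound 2 to compound 4 (1.16 log units; beyond the scatter). Among the compounds shown, the two one-carbon groups now both sit at the limit, the cyclopropyl and isopropyl compounds do not, and the step between compound 1 and compound 4 cannot be read: the limit of > 100000 nM in this assay, at which 2 of the 4 values shown sit.

On these data alone, how compound 1 and compound 4 would order beyond the limit stays open. Also open, as far as these compounds go, is whether ethyl, a longer chain, an amine or a carboxylic acid at this carbon would give a number or stay at the limit.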